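Dichloroacetanilide series on gastric carcinoma cells: working notes

The compounds below may be only part of what the source reports. "The series", "measured", "known", "first", "only" and "open" are said of these compounds alone.

Measured so far:
compound 1, `O=C(Nc1cccc(Br)c1)C(Cl)Cl`, 95300 nM
compound 2, `O=C(Nc1cccc(I)c1)C(Cl)Cl`, 58800 nM

Both compounds share the dichloroacetamide and a six-membered aromatic ring of carbon only, differing in the single substituent on that ring. In a functional assay on BGC-823 cells (Homo sapiens) for antiproliferative activity, read by MTT assay, with a stated time of 72 h (a lower number here means a stronger inhibitor, a higher number a weaker inhibitor), compound 1 gives 95300 nM, and compound 2 gives 58800 nM. The step of a 1.6-fold lower number from compound 1 to compound 2 (0.21 log units; within the scatter) is within the scatter, so the two numbers cannot be ordered, and compound 2 cannot be called the stronger of the pair; it merely has the lower of the two numbers.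

Compound 3, `O=C(Nc1cccc(OC(F)(F)F)c1)C(Cl)Cl`, is the next member: trifluoromethoxy in place of iodo on an aromatic carbon. Among the compounds with values here, no measured step involves a trifluoromethoxy group, so the only step that bears on this change is the exchange of one ring substituent for another in a 1.6-fold lower number from compound 1 to compound 2 (0.21 log units; within the scatter), which stayed within the scatter. On that basis no step beyond the scatter is expected in this assay for compound 3; the expected step of a 1.0-fold higher number from compound 2 to compound 3 (0.01 log units; within the scatter) is small. Compound 3 is thus estimated at 60000 nM, with a range from 20000 nM to 180000 nM.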

Compound 3, half-maximal inhibitory concentration: 142000 nM
The estimate for compound 3 lay 2.4-fold (0.37 log units) below the measured number; the measured number falls inside the stated range.
By their numbers in this assay, from the lowest: compounds 2, 1 and 3 (each within the scatter of the next, the first and the last beyond it).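

In this assay the exchange of one substituent for another on an aromatic carbon, meta to a group of 6 heavy atoms, now gives its first step beyond the scatter: a 2.4-fold higher number from compound 2 to compound 3 (0.38 log units; beyond the scatter) and, though modest, it shows that this position does not tolerate every exchange without a change in the number. Within the data shown here, the exchange of bromo for trifluoromethoxy behaves differently, with a 1.5-fold higher number from compound 1 to compound 3 (0.17 log units; within the scatter) in the same assay, so these two groups cannot be ordered and compound 1 cannot be separated from either compound 2 or compound 3; only the pair compound 2 and compound 3 stands apart. No measurement is available that accounts for the difference between the iodo and trifluoromethoxy compounds.

The compounds shown carry only bromo, iodo and trifluoromethoxy at this one place, so it remains open whether an amine, a carboxylic acid or a longer alkoxy chain there would give a number clearly apart from these. From the compounds shown here alone, it also remains open how the same three groups would behave elsewhere on the ring, and whether the modest step from iodo to trifluoromethoxy would hold with another acyl group in place of the dichloroacetamide.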